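Swapping bromo for methoxy on a cytotoxic fused core

This account rests on a few compounds, and the source may have more. Where it says the series, first, only, none or still open, it means among the compounds named here.

compound 1 `Brc1cccc2cc3c(nc12)-c1nc2ccccc2n1C3`: 11300 nM
compound 2 `Cc1ccc2cc3c(nc2c1)-c1nc2ccccc2n1C3`: > 100000 nM

Both compounds were tested in a functional assay on MDA-MB-231 cells (Homo sapiens) for cytotoxicity, read by MTT assay, with a stated time of 72 h; on this read-out lower numbers stand for stronger inhibition and higher numbers for weaker inhibition. Going by the values given here, compound 1 gives the only actual number, 11300 nM.

Compound 2 reads > 100000 nM, which is a limit of the assay and not a number.

Among the compounds with values here, no pair of measured compounds forms a single-change step, so there is no direct guide to how much one substitution matters here.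

Compound 3 `COc1cccc2cc3c(nc12)-c1nc2ccccc2n1C3` has not yet been measured in this assay. It keeps the core of compound 1 and changes one group: methoxy in place of bromo on an aromatic carbon. In words, this is methoxy in place of bromo on an aromatic carbon.

A weakening is expected, though the evidence for it is thin. Within the data shown here, compound 1, at 11300 nM, is the only measured compound with a number, so a weaker result seems likelier than a stronger one. The expected change is a 3.1-fold higher number from compound 1 to compound 3 (0.49 log units; beyond the scatter), modestly beyond the scatter.

For compound 3 the estimated value is 35000 nM, with an expected range from 8000 nM to 100000 nM.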

Compound 3, half-maximal inhibitory concentration: > 100000 nM
Compound 3 was reported as a limit; the forecaster's own chance of this, stated with the estimate: 30%; middle value at least 2.8-fold (0.45 log units) away from the limit.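

Compound 3 reads > 100000 nM in this assay, which is a limit of the assay and not a number. Even so, it gives the first single-change step among these compounds, and so the first direct look at this position: methoxy in place of bromo on an aromatic carbon, ortho to a fused ring and meta to a fused ring, brings an at least 8.8-fold higher number from compound 1 to compound 3 (0.94 log units; beyond the scatter), which shows that the measurable cytotoxicity of compound 1 does not survive this swap. The step has only a lower end and its full size cannot be read, because compound 3 sits at a limit: the limit of > 100000 nM in this assay, at which 2 of the 3 values shown sit.

The compounds shown leave open whether bromo is a special case at this carbon or whether other groups, such as a chlorine atom, an amine or a longer chain, would also keep a measurable value. Going by these compounds alone, with compound 1 at 11300 nM as the only actual number, they also do not show whether any replacement on this carbon could give a lower number than bromo does.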